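A few compounds are considered here, and "the series" means these few. Any claim that something is new, unique, unknown or untested is made for them only; others in the source may bear on it.

Among the measured compounds shown here, the three compounds measured so far share a lactone core carrying two side chains, and they differ only in the ester at the end of the longer chain. Compound 1 `CC(=O)O[C@@H]1C=CC(=O)O[C@@H]1[C@@H](COC(=O)c1ccc(Cl)cc1)OC(C)=O` gives in a functional assay on HeLa cells (Homo sapiens) for antiproliferative activity, read by MTT assay, with a stated time of 6 days (on this read-out lower numbers stand for stronger inhibition and higher numbers for weaker inhibition), a value of 11000 nM. Compound 2 `O=C1C=C[C@@H](OCc2ccccc2)[C@@H]([C@@H](COC(=O)/C=C/c2ccccc2)OCc2ccccc2)O1` gives in this assay a value of 9510 nM. Compound 3 `COc1ccc(/C=C/C(=O)OC[C@@H](OCc2ccccc2)[C@H]2OC(=O)C=C[C@H]2OCc2ccccc2)cc1` gives in this assay a value of 1080 nM, the lowest of the three numbers; its nearest neighbour is compound 2 and its most distant is compound 1, both steps lying beyond the scatter.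

Compound 4 `O=C1C=C[C@@H](OCc2ccccc2)[C@@H]([C@@H](COC(=O)/C=C/c2ccc(F)cc2)OCc2ccccc2)O1` has not yet been measured in this assay. It differs from compound 3 in one place: fluoro in place of methoxy on an aromatic carbon. For the measured compounds named here, only one of the measured steps touches this position, the step of an 8.8-fold lower number from compound 2 to compound 3 (0.94 log units; beyond the scatter), in which methoxy entered in place of hydrogen. Going by the values given here, no measured step shows what fluoro does at this carbon, so the expectation rests on compound 2 and compound 3 bracketing the possible outcome. The number for compound 4 is expected to rise somewhat above that of compound 3, by about a 3.7-fold higher number from compound 3 to compound 4 (0.57 log units; beyond the scatter), since the group that gave the gain is removed and a smaller one enters. Compound 4 is therefore estimated at 4000 nM, within a range of 1000 nM to 15000 nM.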

Compound 4, half-maximal inhibitory concentration: 7310 nM
Compound 4: middle estimate off by 1.8-fold (0.26 log units), on the low side; the measured number falls inside the stated range.
By their numbers in this assay, from the lowest: compound 3; then compounds 4, 2 and 1 (each within the scatter of the next).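

The exchange of 4-methoxyphenyl for 4-fluorophenyl gives a 6.8-fold higher number from compound 3 to compound 4 (0.83 log units; beyond the scatter) and so adds a second measured step at this carbon, showing that the gain seen with methoxy does not carry over to every replacement of hydrogen there. Fluoro in place of hydrogen gives a 1.3-fold lower number from compound 2 to compound 4 (0.11 log units; within the scatter) and therefore leaves compound 4 and compound 2 indistinguishable, which the earlier compounds could not show, since no fluoro compound stood among them. Among compound 2, compound 3 and compound 4, then, only the methoxy compound stands apart at this carbon, and that holds for just these three substituents, so it is no general rule for the position; nothing at hand explains why methoxy separates from fluoro and hydrogen here.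

The compounds shown leave open whether an ethoxy group, a hydroxyl group or a dimethylamino group at this carbon would side with methoxy or with fluoro and hydrogen. They also leave open whether methoxy would give a similar step on another carbon of the same ring, or whether a chlorine atom at this carbon would behave like fluoro.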